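Replacing cyclohexyl by a dimethylaminoethyl chain on the ring nitrogen

The source may report more compounds than this note shows. Statements on the series, on what has been measured and on what is new or still open speak of the compounds shown alone.

Of the compounds shown here, two with a shared core have been measured in an assay on CHO cells for displacement of a labelled ligand from adenosine receptor A1 (Homo sapiens), read by scintillation counting, with a stated time of 1 h, tested at 1 uM; a higher number here means more inhibition at the concentration tested (going by the name of the read-out), a lower number less inhibition. Compound 1 `O=C(Nc1ncc(-c2cccc(Cl)c2)c(-c2ccccc2)n1)C1CCCC1` gives 47%, and compound 2 `Clc1cccc(-c2cnc(NC3CCCCC3)nc2-c2ccccc2)c1` gives 58%. Compound 2 thus holds the higher of the two numbers; the only step shown, a number 11 percentage points higher from compound 1 to compound 2 (beyond the scatter), is the change of the substituent on the nitrogen on the aromatic ring. Compound 3 `CN(C)CCNc1ncc(-c2cccc(Cl)c2)c(-c2ccccc2)n1` differs from compound 2 at that same nitrogen: 2-(dimethylamino)ethyl in place of cyclohexyl on a nitrogen on an aromatic ring. Among the measured compounds shown here, the single measured step concerns a different swap at this position, so it shows only that changes there can move the read-out by a modest amount; it gives no direction for the present change. On that basis compound 3 is expected to come out near compound 2 or somewhat lower, with an estimated step of a number 13 percentage points lower from compound 2 to compound 3 (beyond the scatter). The estimate for compound 3 is 45%, in a range from 20% to 70%.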

Compound 3, a percentage reported as inhibition, at one concentration (the size of the read-out at that concentration, not a potency): 52%
Beside the measured number, compound 3's estimate is 7 percentage points below it, and the stated range covers the measured number.
By their numbers in this assay, from the lowest: compounds 1, 3 and 2 (each within the scatter of the next, the first and the last beyond it).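

In this assay, the open 2-(dimethylamino)ethyl chain on this nitrogen takes the place of the cyclohexyl ring with a number 6 percentage points lower from compound 2 to compound 3 (within the scatter), so at this position the read-out does not need that carbon ring and survives a second nitrogen in the substituent. The comparison with the amide gives a number 5 percentage points higher from compound 1 to compound 3 (within the scatter), which means that compound 3 cannot be told apart from either compound 1 or compound 2, even though those two differ beyond the scatter. No measured evidence here accounts for how closely these different groups match.

The compounds shown leave open whether a longer chain, a morpholine ring at the chain end or a terminal carboxylic acid would separate from these groups. Since each number comes from a single concentration, they also leave the potency of compound 3 unsettled.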